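Fluoro for Methoxy on the Benzyl Arm

The compounds below may be only part of what the source reports. "The series", "measured", "known", "first", "only" and "open" are said of these compounds alone.

The compounds share one core. Compound 1 `Cc1ccc(-c2nc(N)c3cc(Cc4ccccc4F)sc3n2)o1` carries a 2-fluorobenzyl group, and in a functional assay on CHO-K1 cells for antagonist activity at adenosine receptor A1 (Homo sapiens), read by a beta-galactosidase reporter and cAMP accumulation, with stated times of 15 min and 6 h (a higher number here means a weaker inhibitor, a lower number a stronger inhibitor), compound 1 reaches only the assay's limit, < 16 nM. Compound 2 `COc1ccccc1Cc1cc2c(N)nc(-c3ccc(C(F)F)o3)nc2s1` gives 516 nM in this assay. Compound 3 `COc1ccccc1Cc1cc2c(N)nc(-c3cccc(C#N)c3)nc2s1` gives 129 nM, the lowest of the two proper numbers, and the step of a 4.0-fold lower number from compound 2 to compound 3 (0.60 log units; beyond the scatter) lies beyond the scatter. Compound 4 `N#Cc1cccc(-c2nc(N)c3cc(Cc4ccccc4F)sc3n2)c1` is not yet measured; it differs from compound 3 by fluoro in place of methoxy on an aromatic carbon. Among the compounds with values here, that measured step concerns the aryl group rather than the benzyl arm, so no measured step covers this change directly. Compound 1, which also carries 2-fluorobenzyl, supplies a limit only. The step of a 2.2-fold lower number from compound 3 to compound 4 (0.33 log units; beyond the scatter) is therefore expected to be modest and toward a lower number. Compound 4 is expected to give about 60 nM, within 15 nM to 250 nM.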

Compound 4, inhibition constant: < 16 nM
Compound 4: only a limit was reported; the forecaster's own chance of this, stated with the estimate: 10%; at least 3.7-fold (0.57 log units) between middle value and limit.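

With 2-methoxybenzyl changed to 2-fluorobenzyl, this assay shows an at least 8.0-fold lower number from compound 3 to compound 4 (0.90 log units; beyond the scatter), the only readable step at this position among the compounds shown. The size of this step is a minimum, and the value of compound 4 is a limit: the limit of < 16 nM in this assay, at which 2 of the 4 values shown sit. The step between the two 2-fluorobenzyl compounds cannot be read, so 3-cyanophenyl and 5-methylfuran-2-yl cannot be ranked on this arm.

From the compounds shown here alone, it remains open whether the change holds with the 5-(difluoromethyl)furan-2-yl group. Also open, going by these compounds, is how chloro, hydroxyl or an amine on this carbon would compare with fluoro and methoxy.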